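A Hydroxypropyl Triazole Analogue and Its Expected Cytotoxicity

A few compounds are considered here, and "the series" means these few. Any claim that something is new, unique, unknown or untested is made for them only; others in the source may bear on it.

In an ADME assay on HEK293 cells (Homo sapiens) for cytotoxicity, read by sulforhodamine B assay, with a stated time of 48 h, tested at 10 uM (a lower number here means less inhibition, a higher number more inhibition at the concentration tested (going by the name of the read-out)), compound 1 `COc1nc2ccc(Br)cc2cc1C(c1ccccc1)n1cc(-c2ccccc2)nn1` gives 8.25%, and compound 2 `CCOC(=O)c1cn(C(c2ccccc2)c2cc3cc(Br)ccc3nc2OC)nn1` gives 2%. Within the data shown here, the only measured step, a number 6.3 percentage points lower from compound 1 to compound 2 (within the scatter), leaves these two compounds within the scatter of each other, so compound 2 stands alongside compound 1 rather than apart from it. Compound 3 `COc1nc2ccc(Br)cc2cc1C(c1ccccc1)n1cc(CCCO)nn1` differs from compound 2 by 3-hydroxypropyl in place of ethoxycarbonyl on an aromatic carbon. Among the measured compounds shown here, no measured step involves a 3-hydroxypropyl group; the one step known, also on an aromatic carbon of the core, stayed within the scatter. Compound 3 is therefore expected to show no shift beyond the scatter, with a number 3 percentage points higher from compound 2 to compound 3 (within the scatter). For compound 3 the estimated value is 5%, ranging from 0% to 15%.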

Compound 3, a percentage reported as inhibition, at one concentration (the size of the read-out at that concentration, not a potency): 27.4%
For compound 3 the middle estimate is 22.4 percentage points below the measured one, outside the stated range (above it).
By their numbers in this assay, from the lowest: compounds 2 and 1 (each within the scatter of the next); then compound 3.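

In this assay, among these compounds, the group on this aromatic carbon of the five-membered ring can move the number beyond the scatter, which the one earlier step did not show. 3-Hydroxypropyl in place of ethoxycarbonyl gives a number 25.4 percentage points higher from compound 2 to compound 3 (beyond the scatter), and in place of phenyl it gives a number 19.2 percentage points higher from compound 1 to compound 3 (beyond the scatter). Nothing measured here accounts for this rise. Whether it belongs to the hydroxyl or to the chain itself stays open: a plain propyl group, a longer chain and an amine in place of the hydroxyl are not among the compounds shown.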